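The compounds below may be only part of what the source reports. "The series", "measured", "known", "first", "only" and "open" are said of these compounds alone.

Measured in a functional assay on MDA-MB-231 cells (Homo sapiens) for antiproliferative activity, read by MTT assay, with a stated time of 24 h; a lower number here means a stronger inhibitor, a higher number a weaker inhibitor:
- compound 1 `CC(=O)Oc1ccccc1C(=O)NCC[Se]C#N`: 21100 nM
- compound 2 `CC(=O)Oc1ccccc1C(=O)OCC[Se]C#N`: > 50000 nM (a limit)
- compound 3 `CC(=O)Oc1ccccc1C(=O)[Se]CC[Se]C(=O)c1ccccc1OC(C)=O`: 18600 nM

The values of compound 1 and compound 3 lie within the usual scatter of each other. Compound 2 gives > 50000 nM, which is a limit of the assay and not a number.

Compound 4 `CC(=O)Oc1ccccc1C(=O)[Se]CC[Se]C#N` has not yet been measured. Its change from compound 1 falls on a carbonyl carbon whose other neighbour is an aromatic carbon: a group of 6 heavy atoms (3 carbon, 1 nitrogen, 2 selenium; no ring) in place of a group of 6 heavy atoms (3 carbon, 2 nitrogen, 1 selenium; no ring), on a carbonyl carbon.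

Going by the values given here, the one measured step at this carbonyl carbon is an at least 2.3-fold higher number from compound 1 to compound 2 (0.37 log units; beyond the scatter), which is beyond the scatter and rests on the limit: the limit of > 50000 nM in this assay, at which 1 of the 3 values shown sits. That step replaces the same group as in compound 4, but brings in a different one. Compound 3, which also carries selenium on the carbonyl carbon, gives 18600 nM.

In this assay, a modest step to a lower number is therefore expected, close to the edge of the scatter. The estimate amounts to an expected step of a 2.1-fold lower number from compound 1 to compound 4 (0.32 log units; beyond the scatter). For compound 4 the expected value is 10000 nM, with an estimated range of 3000 nM to 30000 nM.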

Compound 4, half-maximal inhibitory concentration: > 50000 nM
Compound 4 was reported as a limit; the forecaster's own chance of this, stated with the estimate: 8%; middle value at least 5.0-fold (0.69 log units) away from the limit.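

In this assay, placing the group of 6 heavy atoms (3 carbon, 1 nitrogen, 2 selenium; no ring) on the carbonyl carbon gives an at least 2.3-fold higher number from compound 1 to compound 4 (0.37 log units; beyond the scatter), so the loss at this position is not confined to the oxygen-linked compound 2. For compound 4, > 50000 nM is a limit of the assay and not a number. Selenium on the carbonyl carbon is therefore not sufficient on its own, as compound 3, which also carries it there, gives 18600 nM.

Going by these compounds, the step from compound 2 to compound 4 cannot be read, as both values are limits: the limit of > 50000 nM in this assay, at which 2 of the 4 values shown sit. It remains open whether a longer chain, or a carboxylic acid in place of the nitrile, would give a measurable value with selenium on this carbonyl carbon.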